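A Fluorine Atom Added to the Phenyl Ring

The source may hold more compounds than are shown below. What is called first, only, known or untested is meant among the compounds shown, and "the series" means these compounds.

Compound 1 `COc1cc2nc(N3CCCN(C(=O)N4CCOCC4)CC3)cc(N)c2c(-c2ccccc2)c1OC` has been measured in a physicochemical assay for lipophilicity, in phosphate buffer, at pH 7.4 (a lower number here means a more polar compound, a higher number a more lipophilic compound), where compound 1 gives 1.8. Compound 2 `COc1cc2nc(N3CCc4ncccc4C3)nc(N)c2c(-c2ncccn2)c1OC` gives 2.1 in this assay, and the two numbers lie within the scatter of each other, so compound 1 is not set apart from compound 2 on this read-out. Compound 3 `COc1cc2nc(N3CCCN(C(=O)N4CCOCC4)CC3)cc(N)c2c(-c2ccc(F)cc2)c1OC` has not yet been measured. It differs from compound 1 in one place: fluoro in place of hydrogen on an aromatic carbon. Within the data shown here, no measured pair shows this exact change. A small rise in this assay is expected, with the step of a number 0.20 log units higher from compound 1 to compound 3 (within the scatter) sitting at the edge of the scatter. Compound 3 is therefore expected to give 2, between 1.7 and 2.3.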

Compound 3, distribution coefficient: 1.8
For compound 3 the middle estimate is 0.20 log units above the measured one, and the stated range covers the measured number.
By their numbers in this assay, from the lowest: compounds 1, 3 and 2 (each within the scatter of the next).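

In this assay the molecule shows no change at the digits printed from compound 1 to compound 3 (within the scatter) when phenyl becomes 4-fluorophenyl, on an aromatic carbon para to a large group. This pair is the only one here that isolates a single change, which compounds 1 and 2 could not do, and it shows that this position accepts fluoro with no shift that can be told from the scatter. Nothing measured here offers an explanation for this result. Still open, going by these compounds, is how an amine or a carboxylic acid at the same position would read in this assay. Also open, on these data alone, is whether the same fluoro swap would behave alike on the other carbons of this ring.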